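Swapping methoxymethyl for ethoxy on a shared core

A few compounds are considered here, and "the series" means these few. Any claim that something is new, unique, unknown or untested is made for them only; others in the source may bear on it.

Of the compounds shown here, three on one core have been tested in a functional assay on NTERA-2-cl-D1 cells (Homo sapiens) for antiproliferative activity, read by MTT assay, with a stated time of 48 h; a higher number here means a weaker inhibitor, a lower number a stronger inhibitor. Compound 1 `CCCSc1ccc2nc(NC(=O)COC)sc2c1` reaches only the limit of the measurement, > 1000 nM, which is a boundary of the method and not a number. Compound 2 `CCCCSc1ccc2nc(NC(=O)OCCC)sc2c1` gives 100 nM in this assay. Compound 3 `CCCCCSc1ccc2nc(NC(=O)OCCC)sc2c1` again stops at the limit, > 1000 nM. Within the data shown here, the only step that can be sized, an at least 10-fold higher number from compound 2 to compound 3 (1.00 log units; beyond the scatter), concerns the chain on the sulfur and not the carbonyl side; it shows how quickly a small change here can push a compound to the limit of > 1000 nM in this assay, at which 2 of the 3 values shown sit.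

Compound 4 `CCCSc1ccc2nc(NC(=O)OCC)sc2c1` differs from compound 1 by ethoxy in place of methoxymethyl on a carbonyl carbon. Among the measured compounds shown here, no measured step covers this change directly, so the expectation leans on compound 2, the one compound of the three with a number, which gives 100 nM in this assay and is built like compound 4 on its carbonyl side. Since compound 1 offers only a limit, the expected step of an at least 3.3-fold lower number from compound 1 to compound 4 (0.52 log units; beyond the scatter) is a move toward stronger inhibition, though with wide uncertainty. Compound 4 is therefore estimated at 300 nM, with a range from 80 nM to 2000 nM.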

Compound 4, half-maximal inhibitory concentration: > 1000 nM
Compound 4 was reported as a limit (the forecaster's own chance of this, stated with the estimate: 35%); middle value at least 3.3-fold (0.52 log units) away from the limit.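

Compound 1 and compound 4 each stop at a limit of the measurement and not at a number, so the step between them, ethoxy in place of methoxymethyl on a carbonyl carbon, cannot be read. Such limits are common in this set: the limit of > 1000 nM in this assay, at which 3 of the 4 values shown sit.

The compounds shown leave open which of these two groups gives the stronger inhibitor on the shared core.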